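The source may report more compounds than this note shows. Statements on the series, on what has been measured and on what is new or still open speak of the compounds shown alone.

Measured compounds in a functional assay on U-251 cells (Homo sapiens) for antiproliferative activity, read by MTT assay, with a stated time of 24 h; on this read-out higher numbers stand for weaker inhibition and lower numbers for stronger inhibition:

Compound 1, `COc1cc(OC)c(-c2coc3cc(OCC=C(C)C)ccc3c2=O)cc1OC`, gives 3500 nM.
Compound 2, `COc1cccc(C(=O)Oc2ccc3c(=O)c(-c4cc(OC)c(OC)cc4OC)coc3c2)c1`, gives > 10000 nM.
Compound 3, `COc1cc(OC)c(-c2coc3cc(OCc4ccccc4F)ccc3c2=O)cc1OC`, gives 2890 nM.

Compound 2 stands at a limit of this assay rather than at a number, as the limit of > 10000 nM in this assay, at which 1 of the 3 values shown sits, records; of the three compounds it alone sits there. The unmeasured compound 4, `COc1cc(OC)c(-c2coc3cc(OCc4ccc(Cl)cc4)ccc3c2=O)cc1OC`, is reached from compound 2 by the change (4-chlorobenzyl in place of (3-methoxyphenyl)carbonyl on an oxygen on an aromatic ring).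

For the measured compounds named here, two measured steps bear on it. The closest is an at least 3.4-fold lower number from compound 2 to compound 3 (0.53 log units; beyond the scatter), which swaps the same leaving group for a benzyl group bearing a halogen and brings the number down from the limit to a measured value. The step of an at least 2.8-fold higher number from compound 1 to compound 2 (0.45 log units; beyond the scatter) shows the reverse movement when the (3-methoxyphenyl)carbonyl group enters. The comparison a 1.2-fold lower number from compound 1 to compound 3 (0.08 log units; within the scatter) shows that exchanging the 2-methylprop-1-en-1-yl piece for an aryl piece on that carbon changes little.

For compound 4 a step of the same kind as the step from compound 2 to compound 3 is therefore expected in this assay, namely a lower number, at least modest in size, leaving the limit behind: an at least 3.5-fold lower number from compound 2 to compound 4 (0.55 log units; beyond the scatter). Compound 4 is estimated at 2800 nM, with a range from 1200 nM to 7000 nM.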

Compound 4, half-maximal inhibitory concentration: 470 nM
Compound 4: the middle estimate sits 6.0-fold (0.78 log units) above what was measured; measured number outside the range, below it.
By their numbers in this assay, from the lowest: compound 4; then compounds 3 and 1 (each within the scatter of the next). At a limit, above all of these: compound 2.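

In this assay, the oxygen on the aromatic ring of the shared core proves more sensitive to the choice of aryl group than compounds 1 and 3 suggested: these two lie within the scatter of each other, yet the 4-chlorophenyl piece on the saturated chain carbon gives a 6.1-fold lower number from compound 3 to compound 4 (0.79 log units; beyond the scatter) and a 7.4-fold lower number from compound 1 to compound 4 (0.87 log units; beyond the scatter). Against the (3-methoxyphenyl)carbonyl group, the change to 4-chlorobenzyl gives an at least 21-fold lower number from compound 2 to compound 4 (1.32 log units; beyond the scatter), the largest step shown in this series, and compound 4 has the lowest number of the four, with its steps to all the others beyond the scatter. The size of that largest step has only a lower bound, since compound 2 stands at a limit and not at a number: the limit of > 10000 nM in this assay, at which 1 of the 4 values shown sits.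

Compounds 3 and 4 differ in both the halogen and its place on the benzyl ring, so the compounds shown cannot separate these two changes; a 2-chlorobenzyl or 4-fluorobenzyl group would be needed to do so. Also open, going by these compounds, is how an unsubstituted benzyl group, or a benzyl group carrying an amine or a carboxylic acid, would read in this assay.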